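Tolerance Outlook for a Benzyl Analogue in Liver Cells

A few compounds are considered here, and "the series" means these few. Any claim that something is new, unique, unknown or untested is made for them only; others in the source may bear on it.

Measured compounds:
compound 1 `Cc1ccccc1-c1nn(Cc2ccc(F)cc2)cc1CNCCN1CCN(C)CC1` — > 20000 nM
compound 2 `Cc1ccccc1-c1nn(-c2ccc(F)cc2)cc1CNCCN1CCN(C)CC1` — > 20000 nM
compound 3 `Cc1ccc(-n2cc(CNCCN3CCN(C)CC3)c(-c3ccccc3C)n2)c(C)c1` — > 20000 nM

Each of these three values in an ADME assay on Huh-7 cells (Homo sapiens) for cytotoxicity (a higher number here means that more compound is tolerated, a lower number that less compound is tolerated), is a limit of the assay and not a number. Compound 3 therefore stands at the limit, and so do the other two measured compounds, as the limit of > 20000 nM in this assay, at which 3 of the 3 values shown sit, records. Within the data shown here, three steps bear on the change under study: a step that the two limits leave unreadable from compound 1 to compound 2, a step that the two limits leave unreadable from compound 1 to compound 3 and a step that the two limits leave unreadable from compound 2 to compound 3. None of them can be read, as both ends of each sit at the same limit; they show only that exchanging one group on the aromatic nitrogen for another has not brought any of these compounds into the measurable range.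

Compound 4 `Cc1ccccc1-c1nn(Cc2ccccc2)cc1CNCCN1CCN(C)CC1` differs from compound 3 by benzyl in place of 2,4-dimethylphenyl on an aromatic nitrogen. With the three measured steps unreadable, no step beyond the scatter is expected in this assay in either direction; the expected step from compound 3 to compound 4 is a number no higher from compound 3 to compound 4 (the limit leaves the size open). Compound 4 is accordingly estimated at 20000 nM, with a range from 10000 nM to 60000 nM, and most probably the assay will again report only a limit.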

Compound 4, half-maximal cytotoxic concentration: > 20000 nM
Compound 4 gave a limit, no number; the forecaster's own chance of this, stated with the estimate: 85%; the middle value sits exactly at the limit.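

No new step can be read from compound 4 to compound 1, compound 2 or compound 3, since all four compounds sit at the same limit: the limit of > 20000 nM in this assay, at which 4 of the 4 values shown sit.

The compounds shown leave open what concentration any of them would reach in this assay, and whether any group on the aromatic nitrogen would give a measurable value.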